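Thromboxane synthase inhibitors: alkene chain series, next analogue

The compounds below may be only part of what the source reports. "The series", "measured", "known", "first", "only" and "open" are said of these compounds alone.

Measured so far:
compound 1, `O=C(O)C(CCC/C=C(\c1ccccc1)c1cccnc1)Sc1ccccc1`, 33 nM
compound 2, `C/C(=C\CCCCC(=O)O)c1cccnc1`, 210 nM

Within the data shown here, in an assay (Equus caballus) for inhibition of Thromboxane-A synthase (Homo sapiens), using microsomes (a higher number here means a weaker inhibitor, a lower number a stronger inhibitor), compound 2 stands highest of the two numbers; compound 1 gives the only other value, a gap well beyond the scatter. Compound 3, `O=C(O)CCCC/C=C(/c1cccnc1)c1cccs1`, is not yet measured. It differs from compound 2 as follows: thiophen-2-yl in place of methyl on a double-bonded chain carbon bound to an aromatic carbon and a double-bonded chain carbon. Since compound 1, which also carries a ring on the double-bonded chain carbon, gives 33 nM in this assay, the step from compound 2 to compound 3 is expected to be downward and beyond the scatter, a 4.2-fold lower number from compound 2 to compound 3 (0.62 log units; beyond the scatter). Compound 3 is estimated at 50 nM, with a range of 15 nM to 160 nM.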

Compound 3, half-maximal inhibitory concentration: 54 nM
Compound 3: the middle estimate sits 1.1-fold (0.03 log units) below what was measured; the measured number falls inside the stated range.
By their numbers in this assay, from the lowest: compounds 1 and 3 (each within the scatter of the next); then compound 2.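

In this assay, thiophen-2-yl in place of methyl on the double-bonded chain carbon gives a 3.9-fold lower number from compound 2 to compound 3 (0.59 log units; beyond the scatter) and so shows that this position takes a five-membered aromatic ring without loss. Among these compounds, the step is modest, but it is the first change in a single place that can be read. Nothing at hand accounts for the step.

Still open, as far as these compounds go, is whether the aromatic ring matters here or whether any group larger than methyl would do the same. Cyclohexyl or ethyl on this carbon would separate those two readings.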